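From an ether side chain to a fluorinated ring

A few compounds are considered here, and "the series" means these few. Any claim that something is new, unique, unknown or untested is made for them only; others in the source may bear on it.

Measured so far in an ADME assay on Caco-2 cells (Homo sapiens) for permeability, read by LC-MS, in the apical to basolateral direction, with a stated time of 60 min, at pH 6.5; on this read-out higher numbers stand for higher permeability and lower numbers for lower permeability:
Compound 1 `CC(C)(C)OC[C@@H](O)C(=O)N1[C@H](C(=O)NCc2cc(Cl)ccc2-n2cnnn2)C[C@@H]2C[C@@H]21` gives 4.5 10^-6 cm/s
Compound 2 `O=C(O[C@@H](C(=O)N1N=CC[C@H]1C(=O)NCc1cc(Cl)ccc1-n1cnnn1)c1ccc(F)cc1)c1ccccc1` gives 43 10^-6 cm/s
Compound 3 `CC(C)(C)C[C@@H](O)C(=O)N1CC[C@@H]2C[C@@]21C(=O)NCc1cc(Cl)ccc1-n1cnnn1` gives 7.8 10^-6 cm/s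

Repeat measurements of this kind scatter, so small gaps between numbers carry no meaning. Compound 1, at 4.5 10^-6 cm/s, cannot be told apart from compound 3, at 7.8 10^-6 cm/s, since the two lie within the scatter. Compound 2, at 43 10^-6 cm/s, lies beyond the scatter from compound 1 and gives the higher number.

Compound 4 `O=C(NCc1cc(Cl)ccc1-n1cnnn1)[C@@H]1C[C@@H]2C[C@@H]2N1C(=O)[C@H](O)c1ccccc1F` has not yet been measured. Its difference from compound 1 lies in one place: 2-fluorophenyl in place of (tert-butoxy)methyl on a saturated chain carbon bound to a carbonyl carbon and an oxygen on a saturated carbon.

For the measured compounds named here, no pair of measured compounds differs in just one place, so this swap has no direct precedent. Compound 4 differs from compound 2 elsewhere too, although both carry a fluorinated phenyl, which makes the value of compound 2, 43 10^-6 cm/s, a weak guide. Compound 4 keeps the free hydroxyl of compound 1 and compound 3, so no step beyond the scatter is expected in this assay. The expected move is a 1.6-fold higher number from compound 1 to compound 4 (0.19 log units; within the scatter) and it would stay within the scatter. For compound 4 the estimated value is 7 10^-6 cm/s, with an expected range from 2.5 10^-6 cm/s to 20 10^-6 cm/s as its limits.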

Compound 4, apparent permeability: 16 10^-6 cm/s
The estimate for compound 4 lay 2.3-fold (0.36 log units) below the measured number, and the stated range covers the measured number.
By their numbers in this assay, from the lowest: compounds 1 and 3 (each within the scatter of the next); then compound 4; then compound 2.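

In this assay, 2-fluorophenyl in place of (tert-butoxy)methyl on a saturated chain carbon bound to a carbonyl carbon and an oxygen on a saturated carbon gives a 3.6-fold higher number from compound 1 to compound 4 (0.55 log units; beyond the scatter). For the compounds shown here, this is the first single-place change available, and it shows that the read-out responds to the group at this position even when everything else in the molecule stays the same, although the step is only modest. Several things change together in this swap, since an aromatic ring of carbon and a fluorine enter while a chain with a hydrogen-bond acceptor leaves, and no measurement shown gives a reason for the step.

Whether the ring alone accounts for the step or the fluorine takes part stays open, and a plain phenyl in the same place would separate the two. Also open, from the compounds shown here alone, are how the number would respond to an amine or a carboxylic acid at this position, and whether the same swap would give a similar step on the core of compound 3.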